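The source may hold more compounds than are shown below. What is called first, only, known or untested is meant among the compounds shown, and "the series" means these compounds.

Compound 1 `COc1ccc2c(c1)OC(c1cc(OC)c(OC)c(OC)c1)C(C=O)=C2` carries a formyl group on its core. Among the measured compounds shown here, in a functional assay for inhibition of nuclear factor NF-kappa-B complex (Homo sapiens) (on this read-out lower numbers stand for stronger inhibition and higher numbers for weaker inhibition), compound 1 gives 13500 nM, and it is the only compound here to give a number rather than a limit. Compound 2 `COc1ccc2c(c1)OC(c1cc(OC)c(OC)c(OC)c1)C(C(N)=O)=C2` has amino in place of hydrogen on a carbonyl carbon; for compound 2 this assay records only the limit > 50000 nM. Compound 3 `CCNC(=O)C1=Cc2ccc(OC)cc2OC1c1cc(OC)c(OC)c(OC)c1` has ethylamino in place of hydrogen on that carbonyl carbon; for compound 3 this assay likewise records only the limit > 50000 nM. Both changes move toward weaker inhibition, with an at least 3.7-fold higher number from compound 1 to compound 2 (0.56 log units; beyond the scatter) and an at least 3.7-fold higher number from compound 1 to compound 3 (0.56 log units; beyond the scatter), and both end at the limit of > 50000 nM in this assay, at which 2 of the 3 values shown sit. Between the two, a step that the two limits leave unreadable from compound 2 to compound 3 cannot be read. Compound 4 `COc1ccc2c(c1)OC(c1cc(OC)c(OC)c(OC)c1)C(C(=O)NC(C)C)=C2` differs from compound 1 by isopropylamino in place of hydrogen on a carbonyl carbon. Given an at least 3.7-fold higher number from compound 1 to compound 2 (0.56 log units; beyond the scatter) and an at least 3.7-fold higher number from compound 1 to compound 3 (0.56 log units; beyond the scatter), the step is expected to be a 5.2-fold higher number from compound 1 to compound 4 (0.71 log units; beyond the scatter), toward weaker inhibition. Compound 4 is therefore estimated at 70000 nM, within 30000 nM to 250000 nM, most likely reported only as a limit.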

Compound 4, half-maximal inhibitory concentration: > 50000 nM
Compound 4: no number, only a limit; the forecaster's own chance of this, stated with the estimate: 80%; the middle value lies beyond the limit too.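

Moving from formyl to isopropylcarbamoyl gives an at least 3.7-fold higher number from compound 1 to compound 4 (0.56 log units; beyond the scatter), so the larger isopropyl group on the amide-type nitrogen follows the same direction as the two smaller amides and restores no readable inhibition. In this assay compound 4 records only a limit, > 50000 nM, not a number. The steps among compound 2, compound 3 and compound 4 cannot be read, so nothing can be said about how the size of the nitrogen substituent matters, because all three sit at the same ceiling: the limit of > 50000 nM in this assay, at which 3 of the 4 values shown sit.

On these data alone, how far beyond that limit each amide lies stays open. As far as these compounds go, it is also open whether any other group on this carbonyl carbon, such as a methyl ketone, a methyl ester or a carboxylic acid, would give a readable number as the formyl of compound 1 does.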